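The source may report more compounds than this note shows. Statements on the series, on what has been measured and on what is new or still open speak of the compounds shown alone.

Within the data shown here, in an assay for inhibition of steroid 17-alpha-hydroxylase/17,20 lyase (Homo sapiens), read by HPLC, with a stated time of 5 min, tested at 2.5 uM, in the presence of a further agent that is not named here (on this read-out lower numbers stand for less inhibition and higher numbers for more inhibition at the one concentration tested (going by the name of the read-out)), compound 2 `CC(C)Oc1ccc(COc2ccc3c(Cn4ccnc4)cc(=O)oc3c2)cc1` gives 2%; the only other number is that of compound 1 `COc1ccc(COc2ccc3c(Cn4ccnc4)cc(=O)oc3c2)cc1`, which gives 1%, and the step of a number 1 percentage points higher from compound 1 to compound 2 (within the scatter) stays within the scatter. Compound 3 `CCCOc1ccc(COc2ccc3c(Cn4ccnc4)cc(=O)oc3c2)cc1` differs from compound 2 by propyl in place of isopropyl on an oxygen on an aromatic ring. Among the measured compounds shown here, the one measured step, a number 1 percentage points higher from compound 1 to compound 2 (within the scatter), bears on this change since it alters the same group on the same oxygen, and it was too small to matter. Compound 3 is therefore expected to show no step beyond the scatter, no change at the digits printed from compound 2 to compound 3 (within the scatter). The estimate for compound 3 is 2%, ranging from 0% to 8%.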

Compound 3, a percentage reported as inhibition, at one concentration (the size of the read-out at that concentration, not a potency): 2%
For compound 3 middle estimate and measured number coincide at the digits printed, and the stated range covers the measured number.
By their numbers in this assay, from the lowest: compounds 1, 2 and 3 (each within the scatter of the next).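

In this assay, propyl in place of isopropyl on the oxygen gives no change at the digits printed from compound 2 to compound 3 (within the scatter), so the branched and unbranched chains cannot be told apart here. Ethyl in place of hydrogen on a saturated chain carbon bound to the oxygen gives a number 1 percentage points higher from compound 1 to compound 3 (within the scatter), so going from the methoxy to the propoxy compound also produces no readable step. No supporting data bear on why these compounds read alike. From the compounds shown here alone, whether a longer chain, an amine or a carboxylic acid at this position would give a step beyond the scatter remains open.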